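Chalcone series: diethylamino to trifluoromethyl replacement

A few compounds are considered here, and "the series" means these few. Any claim that something is new, unique, unknown or untested is made for them only; others in the source may bear on it.

Measured compounds:
compound 1, `CCN(CC)c1ccc(/C=C/C(=O)c2ccc(OC)c3c2OC(C)(C)C=C3)cc1` — 550 nM
compound 2, `COc1ccc(C(=O)/C=C/c2ccc3ccccc3n2)c2c1C=CC(C)(C)O2` — 3790 nM

In a functional assay on HT-29 cells (Homo sapiens) for antiproliferative activity, read by MTT assay, with a stated time of 24 h (on this read-out lower numbers stand for stronger inhibition and higher numbers for weaker inhibition), compound 1 gives 550 nM and holds the lowest number of the two measured compounds. Going by the values given here, compound 2 in this assay gives 3790 nM, a gap from compound 1 that lies beyond the scatter; no single-point step links these two, so the pair shows only that the aryl-terminus variant of compound 1 inhibits more strongly than the quinolinyl variant of compound 2.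

Compound 3, `COc1ccc(C(=O)/C=C/c2ccc(C(F)(F)F)cc2)c2c1C=CC(C)(C)O2`, shares the core of compound 1 and differs from it in one place: trifluoromethyl in place of diethylamino on an aromatic carbon, the position described as an aromatic carbon of a six-membered aromatic ring of carbon only, para to a large group. Among the compounds with values here, no measured step of this kind is available.

Removal of the diethylamino group is expected to cost potency, with a step upward in the number; the estimated step from compound 1 to compound 3 is a 2.9-fold higher number from compound 1 to compound 3 (0.46 log units; beyond the scatter), beyond the scatter but smaller than the gap to compound 2. Compound 3 is accordingly estimated at 1600 nM in this assay, within a range of 500 nM to 5000 nM.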

Compound 3, half-maximal inhibitory concentration: > 10000 nM
Compound 3: a limit, no number (the forecaster's own chance of this, stated with the estimate: 5%); middle value at least 6.2-fold (0.79 log units) from the limit.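

Trifluoromethyl in place of diethylamino, on an aromatic carbon of a six-membered aromatic ring of carbon only, para to a large group, is the first change in the series made in one place, and in this assay it gives an at least 18-fold higher number from compound 1 to compound 3 (1.25 log units; beyond the scatter). This position is therefore not indifferent to what it carries: with the shared core unchanged, this one exchange takes the read-out from a measured number to no number at all. The reading for compound 3 is a limit of the assay and not a number: the limit of > 10000 nM in this assay, at which 1 of the 3 values shown sits.

A single exchange cannot separate the loss of diethylamino from the arrival of trifluoromethyl, and the step has no upper end. Whether dimethylamino, a cyclic amine such as pyrrolidine or morpholine, or a methoxy group at this position would hold the activity of compound 1 remains open, as does any cause for the step.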